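The source may hold more compounds than are shown below. What is called first, only, known or untested is meant among the compounds shown, and "the series" means these compounds.

Working notes on the series. Compound 1 `CCCC(C(=O)O)c1cnc2sc(C)cc2c1-c1ccc(C)cc1` has been measured in an ADME assay on MT4 cells (Homo sapiens) for cytotoxicity, read by MTT assay (a lower number here means that less compound is tolerated, a higher number that more compound is tolerated), and gives 72200 nM. Within the data shown here, the only other measured member, compound 2 `CCCC(C(=O)O)c1c(C)nc2ccc(Cl)cc2c1-c1ccccc1`, gives 67300 nM in this assay; the two numbers lie within the usual scatter of each other, so neither compound can be separated from the other on tolerance, and no step is drawn between them.

Compound 3 `Cc1ccc(-c2c(C(OC(C)(C)C)C(=O)O)cnc3sc(C)cc23)cc1` is not yet measured. It differs from compound 1 by tert-butoxy in place of propyl on a saturated chain carbon bound to an aromatic carbon and a carbonyl carbon. Among the measured compounds shown here, no measured pair in the set carries a change of this kind, so the data give nothing against which to size it. The step from compound 1 to compound 3 in this assay is expected to be a 1.1-fold lower number from compound 1 to compound 3 (0.05 log units; within the scatter), that is, none beyond the scatter. The estimate for compound 3 in this assay is 65000 nM, with a range from 25000 nM to 160000 nM.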

Compound 3, half-maximal cytotoxic concentration: 96000 nM
Compound 3: the middle estimate sits 1.5-fold (0.17 log units) below what was measured; the measured number falls inside the stated range.
By their numbers in this assay, from the lowest: compounds 2, 1 and 3 (each within the scatter of the next).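

In this assay, the first step read at this position is a 1.3-fold higher number from compound 1 to compound 3 (0.12 log units; within the scatter). Among these compounds, this is the first sign that a saturated chain carbon bound to an aromatic carbon and a carbonyl carbon can carry tert-butoxy in place of propyl, oxygen and hydrogen-bond acceptor included, with no separation in tolerance on the core of compound 1. As this rests on a single pair, it describes this one change only, and no measurement at hand bears on the reason for it.

Going by these compounds, whether an amine or a longer chain on this carbon would give a step beyond the scatter remains open. Also open, on these data alone, is whether tert-butoxy in place of propyl gives the same reading on the core of compound 2, or how the change reads in any measure other than this assay.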